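N-Methylation of the aminopyrimidine in a biaryl series

The source may hold more compounds than are shown below. What is called first, only, known or untested is meant among the compounds shown, and "the series" means these compounds.

Compound 1 `Nc1ncc(-c2cccc(Cl)c2)c(-c2ccccc2)n1` is known in an assay on CHO cells for displacement of a labelled ligand from adenosine receptor A1 (Homo sapiens), read by scintillation counting, with a stated time of 1 h, tested at 1 uM (on this read-out higher numbers stand for more inhibition at the one concentration tested (going by the name of the read-out) and lower numbers for less inhibition), only as a limit: compound 1 gives > 80%. Compound 2 `COc1ccc(-c2cnc(N)nc2-c2ccccc2)cc1Cl` also sits at a limit, giving > 80% in this assay. The step that the two limits leave unreadable from compound 1 to compound 2 cannot be read because of the limit of > 80% in this assay, at which 2 of the 2 values shown sit. Compound 3 `CNc1ncc(-c2cccc(Cl)c2)c(-c2ccccc2)n1` differs from compound 1 in one place: methyl in place of hydrogen on a nitrogen on an aromatic ring. No measured step touches the nitrogen on the aromatic ring, so nothing shown gives a size or direction for this change in this assay. Compound 3 is expected to give 70% (35% to 95%), the step of a number at least 10 percentage points lower from compound 1 to compound 3 (that floor lies within the scatter) being an estimate only.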

Compound 3, a percentage reported as inhibition, at one concentration (the size of the read-out at that concentration, not a potency): 75%
For compound 3 the middle estimate is 5 percentage points below the measured one, and the stated range covers the measured number.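

Among these compounds, at the nitrogen on an aromatic ring, the change from amino to methylamino gives the first step with a stated floor in this assay: a number at least 5 percentage points lower from compound 1 to compound 3 (that floor lies within the scatter). Compound 3 gives 75%, a plain number rather than a limit, so methyl on this nitrogen is compatible with substantial inhibition at the one concentration tested. The full size of the step stays unknown because compound 1 sits at a limit: the limit of > 80% in this assay, at which 2 of the 3 values shown sit.

From the compounds shown here alone, whether ethyl, a longer chain or dimethylamino at this place keeps that inhibition stays open. The step between the two compounds at the limit remains unreadable.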